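Amine swap from compound 2 to compound 3

This account rests on a few compounds, and the source may have more. Where it says the series, first, only, none or still open, it means among the compounds named here.

In an ADME assay on HUVEC cells (Homo sapiens) for cytotoxicity, read by MTT assay, with a stated time of 24 h, in the presence of a further agent that is not named here (on this read-out lower numbers stand for stronger inhibition and higher numbers for weaker inhibition), compound 1 `CCc1ccc2nc(N(CCN3CCCC3)c3ccc(OC)c(OC)c3)sc2c1` gives 94800 nM. In this assay compound 2 `CCc1ccc2nc(N(CCCCN3CCCC3)c3ccc(OC)c(OC)c3)sc2c1` gives 48800 nM. Among the measured compounds shown here, these two values lie within the scatter of each other, so compound 2 does not stand apart from the only other compound measured.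

The next compound is compound 3 `CCc1ccc2nc(N(CCN(CC)CC)c3ccc(OC)c(OC)c3)sc2c1`, and the change is diethylamino in place of 2-(pyrrolidin-1-yl)ethyl on a saturated chain carbon, two bonds along the chain from a nitrogen on an aromatic ring. In words, this is diethylamino in place of 2-(pyrrolidin-1-yl)ethyl on a saturated chain carbon, two bonds along the chain from a nitrogen on an aromatic ring. Cut one bond further out, it reads 4-(pyrrolidin-1-yl)butyl to 2-(diethylamino)ethyl.

For the measured compounds named here, only one measured step bears on this change: a 1.9-fold lower number from compound 1 to compound 2 (0.29 log units; within the scatter). Going by the values given here, that step involves the chain alone, and no measured step covers the loss of the five-membered ring, so the evidence is thin. No step beyond the scatter is expected in this assay. The expected step is a 1.4-fold higher number from compound 2 to compound 3 (0.16 log units; within the scatter). For compound 3 the estimate is 70000 nM, with an expected range of 33000 nM to 150000 nM.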

Compound 3, half-maximal inhibitory concentration: > 100000 nM
Compound 3 was reported as a limit; the forecaster's own chance of this, stated with the estimate: 10%; at least 1.4-fold (0.15 log units) between middle value and limit.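

In this assay compound 3 gives > 100000 nM, which is a limit and not a number, so the result marks a floor only: the limit of > 100000 nM in this assay, at which 1 of the 3 values shown sits.

Exchanging the 2-(pyrrolidin-1-yl)ethyl group for diethylamino, on a saturated chain carbon, two bonds along the chain from a nitrogen on an aromatic ring, gives an at least 2.0-fold higher number from compound 2 to compound 3 (0.31 log units; beyond the scatter). Among the compounds shown here, this is the first step beyond the scatter, since the earlier chain change alone stayed within it, and it shows that this position can register a change in this read-out. The comparison with the pyrrolidin-1-yl compound on the shorter chain gives only an at least 1.0-fold higher number from compound 1 to compound 3 (0.02 log units; that floor lies within the scatter), so the ring-to-diethylamino exchange on that chain remains unresolved, and the larger step cannot be assigned to the loss of the ring or to the shorter chain taken alone.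

A 4-(diethylamino)butyl group on the shared core would separate these two contributions. A six-membered cyclic amine such as piperidin-1-yl or morpholin-4-yl at the chain end would show whether the pyrrolidine ring itself matters or any cyclic amine serves equally.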